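A few compounds are considered here, and "the series" means these few. Any claim that something is new, unique, unknown or untested is made for them only; others in the source may bear on it.

Measured compounds in the series:
- compound 1 `COC(=O)/C=C/c1cccc(N(Cc2ccc(/C=C/c3ccccc3F)cc2)C(=O)C2CCCCC2)c1`: in an assay on isolated protein with Bile acid receptor (Homo sapiens) as the target (on this read-out lower numbers stand for an effect already at smaller amounts and higher numbers for an effect only at larger amounts of compound), compound 1 gives 64 nM
- compound 2 `COC(=O)/C=C/c1cccc(N(Cc2ccc(-c3ccc(OC)cc3)cc2)C(=O)C2CCCCC2)c1`: in this assay compound 2 gives 89 nM

Compound 2 holds the higher of the two numbers; its nearest neighbour is compound 1, and the step of a 1.4-fold higher number from compound 1 to compound 2 (0.14 log units; within the scatter) stays within the scatter, so the two compounds are not separable on these data.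

Compound 3 `COC(=O)/C=C/c1cccc(N(Cc2ccc(-c3cccc(Cl)c3)cc2)C(=O)C2CCCCC2)c1` differs from compound 2 by 3-chlorophenyl in place of 4-methoxyphenyl on an aromatic carbon. For the measured compounds named here, no measured step covers this exact exchange. Going by the values given here, the only step in hand, a 1.4-fold higher number from compound 1 to compound 2 (0.14 log units; within the scatter), replaces the group at the same position and does not move the number beyond the scatter, so for compound 3 a step of about a 1.1-fold higher number from compound 2 to compound 3 (0.05 log units; within the scatter) is expected, with no direction beyond the scatter. The estimate for compound 3 in this assay is 100 nM, with a range from 40 nM to 250 nM.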

Compound 3, half-maximal effective concentration: 94 nM
The estimate for compound 3 lay 1.1-fold (0.03 log units) above the measured number; low and high end bracket the measured number.
By their numbers in this assay, from the lowest: compounds 1, 2 and 3 (each within the scatter of the next).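

In this assay the exchange of 4-methoxyphenyl for 3-chlorophenyl on the aromatic carbon para to a large group gives a 1.1-fold higher number from compound 2 to compound 3 (0.02 log units; within the scatter) and so stays within the scatter, even though the entering group has 0 hydrogen-bond acceptors and the leaving group has 1. The comparison with the ethenyl-linked group gives a 1.5-fold higher number from compound 1 to compound 3 (0.17 log units; within the scatter) and also stays within the scatter, so 2-(2-fluorophenyl)ethenyl, 4-methoxyphenyl and 3-chlorophenyl are not separable at this position. No data at hand offer an explanation for this result.

From the compounds shown here alone, all three groups carry a six-membered aromatic ring of carbon only, so it remains open whether a plain alkyl chain, or a phenyl ring bearing an amine or a carboxylic acid, would give a number beyond the scatter. Going by these compounds, the response to changes elsewhere on the shared core also remains open.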